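Moving the pyridine out by one carbon on the amide side chain

A few compounds are considered here, and "the series" means these few. Any claim that something is new, unique, unknown or untested is made for them only; others in the source may bear on it.

Compound 1, `COc1ccc(Cn2c(CCc3ccccc3)nnc2[C@H](NC(=O)c2ccncc2)c2c[nH]c3ccccc23)cc1`, gives 220 nM in an in vitro assay on LLC-PK1 cells for displacement of a labelled ligand from growth hormone secretagogue receptor type 1 (Homo sapiens); a lower number here means a stronger inhibitor, a higher number a weaker inhibitor.
Compound 2, `COc1ccc(Cn2c(CCc3ccccc3)nnc2[C@H](NC(=O)Cc2ccccn2)c2c[nH]c3ccccc23)cc1`, gives 3 nM in this assay.
Compound 3, `COc1ccc(Cn2c(CCc3ccccc3)nnc2[C@H](NC(=O)Cc2ccncc2)c2c[nH]c3ccccc23)cc1`, gives 270 nM in this assay.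

Compound 3 stands at the highest number of the three, though its gap to compound 1 is within the scatter, as a 1.2-fold higher number from compound 1 to compound 3 (0.09 log units; within the scatter) shows; only compound 2 stands apart, with a 90-fold higher number from compound 2 to compound 3 (1.95 log units; beyond the scatter). Compound 4, `COc1ccc(Cn2c(CCc3ccccc3)nnc2[C@H](NC(=O)CCc2cccnc2)c2c[nH]c3ccccc23)cc1`, differs from compound 3 in one place: (pyridin-3-yl)methyl in place of pyridin-4-yl on a saturated chain carbon bound to a carbonyl carbon. Within the data shown here, two measured steps bear on it. Lengthening the chain while keeping pyridin-4-yl changed little, as seen in the step from compound 1 to compound 3, whereas shifting the ring nitrogen to pyridin-2-yl gave a large change, seen in the step from compound 2 to compound 3. Among the measured compounds shown here, no measured pair shows pyridin-3-yl. He therefore expects compound 4 to land near compound 3, with a modest step at most, estimated as a 1.8-fold lower number from compound 3 to compound 4 (0.26 log units; within the scatter). His estimate for compound 4 in this assay is 150 nM, within 30 nM to 700 nM.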

Compound 4, half-maximal inhibitory concentration: 177 nM
The estimate for compound 4 lay 1.2-fold (0.07 log units) below the measured number, and the stated range covers the measured number.
By their numbers in this assay, from the lowest: compound 2; then compounds 4, 1 and 3 (each within the scatter of the next).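

In this assay, the step to the 2-(pyridin-3-yl)ethyl side chain leaves compound 4 level with the two pyridin-4-yl compounds, as a 1.5-fold lower number from compound 3 to compound 4 (0.18 log units; within the scatter) and a 1.2-fold lower number from compound 1 to compound 4 (0.09 log units; within the scatter) both lie within the scatter. Compound 2 remains apart from this group, with a 59-fold higher number from compound 2 to compound 4 (1.77 log units; beyond the scatter), so among these four compounds only the one carrying (pyridin-2-yl)methyl on the carbonyl carbon stands out, and a pyridin-3-yl ring on a longer chain does not share its number. No measurement shown here offers an explanation for this gap.

The compounds shown leave open whether a 2-(pyridin-2-yl)ethyl group on the carbonyl carbon would keep the number of compound 2. They also leave open whether a benzyl group, with no ring nitrogen at all, would fall nearer compound 2 or nearer compound 3.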